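The source may report more compounds than this note shows. Statements on the series, on what has been measured and on what is new or still open speak of the compounds shown alone.

Measured compounds in an ADME assay on MT4 cells (Homo sapiens) for cytotoxicity, read by MTT assay, with a stated time of 4 days; on this read-out lower numbers stand for higher toxicity in this test and higher numbers for lower toxicity in this test:

- compound 1, `N#Cc1ccc(Nc2nc(N)nc(Oc3ccc(Cl)c4ccccc34)n2)cc1`, gives 237000 nM
- compound 2, `CNc1nc(Nc2ccc(C#N)cc2)nc(Oc2ccc3ccccc3c2)n1`, gives 250000 nM

Of the two numbers recorded so far, that of compound 2 is the higher, but its gap to compound 1 lies within the usual scatter, so the two compounds cannot be told apart in this assay. Among the compounds with values here, both share the same core and differ in two places at once, so no single step between them can be drawn.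

Compound 3, `N#Cc1ccc(Nc2nc(N)nc(Oc3ccc4ccccc4c3)n2)cc1`, has not yet been measured. Relative to compound 2 the change is hydrogen in place of methyl on a nitrogen on an aromatic ring; in words, hydrogen in place of methyl on a nitrogen on an aromatic ring. Within the data shown here, no step between measured compounds covers this change. Both measured compounds sit close together at the high end of the concentration scale, and the change removes only a methyl, so no step beyond the scatter is expected in this assay in either direction. The expected step is a 1.0-fold lower number from compound 2 to compound 3 (0.02 log units; within the scatter). The estimate for compound 3 in this assay is 240000 nM, with a range from 120000 nM to 480000 nM.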

Compound 3, half-maximal cytotoxic concentration: 42200 nM
Compound 3: middle estimate off by 5.7-fold (0.75 log units), on the high side, outside the stated range (below it).
By their numbers in this assay, from the lowest: compound 3; then compounds 1 and 2 (each within the scatter of the next).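

Working from this assay, the change from methylamino to amino gives a 5.9-fold lower number from compound 2 to compound 3 (0.77 log units; beyond the scatter) and so moves the series toward higher toxicity in this test. A nitrogen on an aromatic ring is therefore a place where the loss of a single methyl, one carbon and no ring, registers beyond the scatter, though the step is modest. Compounds 1 and 2 could not show this, as they differ in two places at once and give no step, while their values sit within the scatter of each other; no measurement at hand accounts for the step.

The compounds shown leave open whether the read-out follows the size of the group on this nitrogen, as ethyl or a longer chain in place of methyl would test, or simply separates hydrogen from any carbon group. They also leave open whether methylamino in place of amino on the core of compound 1 would give a step of similar size, so the step stands for this single pair only.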